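A few compounds are considered here, and "the series" means these few. Any claim that something is new, unique, unknown or untested is made for them only; others in the source may bear on it.

Of the compounds shown here, three have so far been measured in an assay on HEK293 cells for inhibition of Voltage-dependent T-type calcium channel subunit alpha-1G (Homo sapiens), read by fluorescence, tested at 10 uM; a higher number here means more inhibition at the concentration tested (going by the name of the read-out), a lower number less inhibition. Compound 1 `CCCc1nc(-c2ccccc2)c(CNCCCN2CCN(c3ccc(F)cc3)CC2)o1` gives 62.5%, the highest of the three numbers. Compound 2 `CCCc1nc(-c2ccccc2)c(CNCCN2CCN(c3ccccn3)CC2)o1` gives 48.1%, and compound 3 `CCCc1nc(-c2ccccc2)c(CNCCN2CCN(c3ccccc3F)CC2)o1` gives 46.5%; both of these sit beyond the scatter below compound 1, so compound 1 stands clearly apart from the other two.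

Compound 4 `CCCc1nc(-c2ccccc2)c(CNCCCN2CCN(c3cccc(Cl)c3)CC2)o1` is the next compound to be measured in this assay. It differs from compound 1 in a single place: 3-chlorophenyl in place of 4-fluorophenyl on an amine nitrogen in a ring. For the measured compounds named here, the only measured step that touches the same place, the aromatic group on the amine nitrogen in a ring, is a number 1.6 percentage points lower from compound 2 to compound 3 (within the scatter), and that step stayed within the scatter. Going by the values given here, compounds 2 and 3 carry a shorter chain than compound 1 and compound 4, so the comparison is not exact, but it is the only guide available.

On that basis the step of a number 2.5 percentage points lower from compound 1 to compound 4 (within the scatter) is expected to stay within the scatter, with no clear direction, because a number 1.6 percentage points lower from compound 2 to compound 3 (within the scatter) showed that exchanging one aromatic ring for another at this place changed little. Compound 4 is therefore estimated to give 60% in this assay, with a range from 42% to 78%.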

Compound 4, a percentage reported as inhibition, at one concentration (the size of the read-out at that concentration, not a potency): 65.9%
Compound 4: the middle estimate sits 5.9 percentage points below what was measured; the measured number falls inside the stated range.
By their numbers in this assay, from the lowest: compounds 3 and 2 (each within the scatter of the next); then compounds 1 and 4 (each within the scatter of the next).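

In this assay, for the compounds shown here, putting 3-chlorophenyl in place of 4-fluorophenyl gives a number 3.4 percentage points higher from compound 1 to compound 4 (within the scatter) and is the first exchange at this place measured on the chain carried by compound 1. Together with a number 1.6 percentage points lower from compound 2 to compound 3 (within the scatter), it means that both exchanges of one aromatic group for another on this amine nitrogen in a ring, one on each chain, stay within the scatter, although only these two pairs can be read and neither separates the effect of the halogen from that of its position on the ring. The two groups have the same count of heavy atoms and the same kind of ring, and no separate measurement is available to explain the small size of this step.

The compounds shown leave open whether a group much unlike these halogen-bearing rings and pyridin-2-yl, such as a phenyl carrying a carboxylic acid or a methoxy group, would also leave the number within the scatter. Going by these compounds alone, no pair here differs only in the chain, so what the chain alone contributes cannot be read from these compounds.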